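The source may report more compounds than this note shows. Statements on the series, on what has been measured and on what is new or still open speak of the compounds shown alone.

Measured so far in an ADME assay on microsomes from liver (Mus musculus), read by LC-MS, using NADPH, with a stated time of 30 min, tested at 1 uM; a lower number here means that less of the compound is left, a higher number that more of the compound is left:
compound 1 `C[C@H](Nc1nc(N)nc(N)c1C#N)c1cc2ccc(F)cn2c(=O)c1-c1ccccc1` gives 42%
compound 2 `C[C@H](Nc1nc(N)ncc1C#N)c1cc2ccc(F)cn2c(=O)c1-c1ccccc1` gives 11%
compound 3 `C[C@H](Nc1ncnc(N)c1C#N)c1c(C2CC2)c(=O)n2cc(F)ccc2c1-c1ccc(F)cc1` gives 52%

Compound 4 `C[C@H](Nc1nc(N)nc(N)c1C#N)c1c(C2CC2)c(=O)n2cc(F)ccc2c1-c1ccc(F)cc1` has not yet been measured in this assay.

One single-point step is available: a number 31 percentage points higher from compound 2 to compound 1 (beyond the scatter), the change being (amino in place of hydrogen on an aromatic carbon). Compound 4 carries the same kind of change against compound 3, namely (amino in place of hydrogen on an aromatic carbon). The surroundings of the place are not identical: from compound 2 to compound 1 the entering group sits next to the ring nitrogen, ortho to a cyano group and opposite the ring nitrogen; in compound 4 it sits between two ring nitrogen atoms and para to a cyano group. The cores of compound 2 and compound 3 differ in more than one place, and that difference is not broken down here. In this assay compound 3 stands nearest compound 1, within the scatter, and well above compound 2.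

The step from compound 3 to compound 4 is expected to run the same way as the measured one but to be smaller, because compound 3 starts from 52% rather than from the level of compound 2, which leaves less room upward. The expected step is a number 15 percentage points higher from compound 3 to compound 4 (beyond the scatter). Compound 4 is accordingly estimated at 67%, with a range from 48% to 86%.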

Compound 4, percent of the compound remaining: 75%
Beside the measured number, compound 4's estimate is 8 percentage points below it, and the stated range covers the measured number.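

In this assay, amino in place of hydrogen, here between two ring nitrogen atoms and para to a cyano group, gives a number 23 percentage points higher from compound 3 to compound 4 (beyond the scatter), and the change carries to this second core in the same direction and with no difference in size that stands out from the scatter: the same change on two cores in this assay, a number 31 percentage points higher (beyond the scatter) from compound 2 to compound 1 and a number 23 percentage points higher (beyond the scatter) from compound 3 to compound 4, 8 percentage points apart, within the scatter of two such steps

This rests on two pairs only, with the amino group entering different surroundings in each, so it is a shift seen twice and not a rule for other cores in the series. The numbers record how much compound remains and give no reason for either step, nor do they show which part of the molecules is lost.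

Open is whether a methylamino group or a hydroxyl group in the same place would give a step of the same kind, as only amino against hydrogen is shown. Also open, on these data alone, is how far this step holds outside this assay.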